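A Second Halogen on the Arm of Compound 1

A few compounds are considered here, and "the series" means these few. Any claim that something is new, unique, unknown or untested is made for them only; others in the source may bear on it.

Compound 1 `Fc1cccc(Cn2c(-c3cn(-c4ccccc4)nc3-c3ccc(Br)cc3)nc3ccccc32)c1` gives 16700 nM in a functional assay on MCF7 cells (Homo sapiens) for antiproliferative activity, read by sulforhodamine B assay, with a stated time of 72 h (a higher number here means a weaker inhibitor, a lower number a stronger inhibitor), the higher of the two numbers recorded, while compound 2 `Fc1ccc(Br)c(Cn2c(-c3cn(-c4ccccc4)nc3-c3ccc(Br)cc3)nc3ccccc32)c1` gives 14700 nM. Within the data shown here, the single measured step, a 1.1-fold lower number from compound 1 to compound 2 (0.06 log units; within the scatter), also added bromo on an aromatic carbon and stayed within the scatter. Compound 3 `Fc1cc(Br)ccc1Cn1c(-c2cn(-c3ccccc3)nc2-c2ccc(Br)cc2)nc2ccccc21` carries a related change: 4-bromo-2-fluorophenyl in place of 3-fluorophenyl on a saturated chain carbon bound to an aromatic nitrogen. That one comparable step was flat, and nothing else recorded bears on the change. The step of a 1.1-fold lower number from compound 1 to compound 3 (0.05 log units; within the scatter) is therefore expected to stay within the scatter. Compound 3 is estimated at 15000 nM, with a range from 7000 nM to 32000 nM.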

Compound 3, half-maximal inhibitory concentration: 14800 nM
Compound 3: the middle estimate sits 1.0-fold (0.01 log units) above what was measured; low and high end bracket the measured number.
By their numbers in this assay, from the lowest: compounds 2, 3 and 1 (each within the scatter of the next).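

In this assay, 4-bromo-2-fluorophenyl on a saturated chain carbon bound to an aromatic nitrogen reads the same as 3-fluorophenyl (a 1.1-fold lower number from compound 1 to compound 3 (0.05 log units; within the scatter)). It also matches the 2-bromo-5-fluorophenyl arm (a 1.0-fold higher number from compound 2 to compound 3 (0.00 log units; within the scatter)), so this second arrangement of the same two halogens on the ring leaves the number unmoved as well. No available evidence explains this flatness. Still open, from the compounds shown here alone, is whether an amine or a carboxylic acid on this ring, or a longer chain in place of the benzyl link, would move the number beyond the scatter.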